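Series notes: phenylpiperazine substituent swap, compound 3 to compound 4

This account rests on a few compounds, and the source may have more. Where it says the series, first, only, none or still open, it means among the compounds named here.

Compound 3 `CC(C)c1ccccc1N1CCN(CCCNc2ncccc2C(=O)N(C)C)CC1` gives 0.398 nM in a functional assay for antagonist activity at Alpha-1A adrenergic receptor (Oryctolagus cuniculus) (on this read-out higher numbers stand for weaker binding and lower numbers for tighter binding), and holds the lowest of the three numbers. Compound 1 `CN(C)C(=O)c1cccnc1NCCCN1CCN(c2ccccc2-c2ccccc2)CC1` gives 1.26 nM and compound 2 `Cc1cnccc1N1CCN(CCCNc2ncccc2C(=O)N(C)C)CC1` gives 200 nM; the steps are a 3.2-fold lower number from compound 1 to compound 3 (0.50 log units; beyond the scatter) and a 500-fold lower number from compound 2 to compound 3 (2.70 log units; beyond the scatter). Compound 4 `CN(C)C(=O)c1cccnc1NCCCN1CCN(c2ccccc2C(F)(F)F)CC1` carries trifluoromethyl in place of isopropyl on an aromatic carbon. Only the modest step of a 3.2-fold lower number from compound 1 to compound 3 (0.50 log units; beyond the scatter) bears on this, as it also exchanges the group on that aromatic carbon; the large step of a 500-fold lower number from compound 2 to compound 3 (2.70 log units; beyond the scatter) exchanges the whole ring and says little here. A change in this assay no larger than a 1.5-fold higher number from compound 3 to compound 4 (0.18 log units; within the scatter) is therefore expected for compound 4, likely within the scatter. Compound 4 is estimated at 0.6 nM in this assay, in the range 0.2 nM to 2 nM.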

Compound 4, dissociation constant: 12.6 nM
Estimate against measurement, compound 4: 21-fold (1.32 log units) below; the whole stated range lies below it.
By their numbers in this assay, from the lowest: compound 3; then compound 1; then compound 4; then compound 2.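

In this assay, the aromatic carbon ortho to a large group does not treat isopropyl and trifluoromethyl alike (a 32-fold higher number from compound 3 to compound 4 (1.50 log units; beyond the scatter)), and trifluoromethyl also falls behind phenyl there (a 10-fold higher number from compound 1 to compound 4 (1.00 log units; beyond the scatter)). The 2-(trifluoromethyl)phenyl group still retains a clear margin over 3-methylpyridin-4-yl (a 16-fold lower number from compound 2 to compound 4 (1.20 log units; beyond the scatter)). No available evidence accounts for these differences.

Going by these compounds, whether a methoxy group or a chlorine atom on this carbon would track isopropyl or trifluoromethyl remains open. On these data alone, whether the order isopropyl, phenyl, trifluoromethyl holds with a longer chain also remains open.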